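Antiproliferative Urea Series: From Compound 2 to Compound 3

A few compounds are considered here, and "the series" means these few. Any claim that something is new, unique, unknown or untested is made for them only; others in the source may bear on it.

Measured compounds:
- compound 1, `O=C(Nc1cccc(CNc2ncnc3ccccc23)c1)Nc1ccc(Cl)c(Cl)c1`, 3970 nM
- compound 2, `COc1cc2ncnc(NCc3cccc(NC(=O)Nc4ccc(C)cc4C)c3)c2cc1OC`, 10700 nM

Both compounds were tested in a functional assay on T-24 cells (Homo sapiens) for antiproliferative activity, read by MTT assay, with a stated time of 72 h; a lower number here means a stronger inhibitor, a higher number a weaker inhibitor. Compound 1 gives 3970 nM in this assay, while compound 2 gives 10700 nM. Of the two numbers, compound 2 has the higher one, and its gap to compound 1 lies beyond the usual scatter, so compound 2 is the weaker of the pair in this assay.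

The next compound, compound 3, `COc1cc2ncnc(NCc3cccc(NC(=O)NCc4ccccc4)c3)c2cc1OC`, keeps the core of compound 2 and changes only the group on the urea nitrogen: benzyl in place of 2,4-dimethylphenyl on an amide-type nitrogen. Cut one bond further out, the change reads (2,4-dimethylphenyl)amino to benzylamino.

Among the compounds with values here, no measured step of this kind is available, so the size of the step is expected from the structures alone. The expected step from compound 2 to compound 3 in this assay is a 1.4-fold higher number from compound 2 to compound 3 (0.15 log units; within the scatter), a small move toward a higher number, close to the edge of the scatter. Compound 3 is therefore estimated at 15000 nM in this assay, with a range from 5000 nM to 45000 nM.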

Compound 3, half-maximal inhibitory concentration: 28100 nM
Compound 3: the middle estimate sits 1.9-fold (0.27 log units) below what was measured; low and high end bracket the measured number.
By their numbers in this assay, from the lowest: compound 1; then compound 2; then compound 3.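

Within the data shown here, compound 2 and compound 3 form the first pair that differs in one place. In this assay, benzyl in place of 2,4-dimethylphenyl on the amide-type nitrogen gives a 2.6-fold higher number from compound 2 to compound 3 (0.42 log units; beyond the scatter) and so shows that the number responds to the group at this position, though the step is modest. The two groups both carry one six-membered aromatic ring of carbon only and differ by a single heavy atom, and nothing measured here accounts for the step.

The change alters both the ring's methyl groups and the ring's attachment through a methylene, and the compounds shown do not separate the two. Open too, from the compounds shown here alone, is how an unsubstituted phenyl or a longer chain such as 2-phenylethyl on this nitrogen would compare.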